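Working notes on a small amide series in a cell assay

The source may hold more compounds than are shown below. What is called first, only, known or untested is meant among the compounds shown, and "the series" means these compounds.

Compound 1 `CCn1c(/C=C2\SC(=O)N(CC(=O)N3CCCCC3)C2=O)nc2ccccc21`: in a functional assay on PC-3 cells (Homo sapiens) for inhibition, read by MTT assay, with a stated time of 48 h (on this read-out lower numbers stand for stronger inhibition and higher numbers for weaker inhibition), compound 1 sits at the limit > 50000 nM, a limit and not a number.
Compound 2 `CCn1c(/C=C2\SC(=O)N(CC(=O)N3CC(C)OC(C)C3)C2=O)nc2ccccc21`: in this assay compound 2 sits at the limit > 50000 nM, again a limit.
Compound 3 `CC(C)n1c(/C=C2\SC(=O)N(CC(=O)N3CCCCC3)C2=O)nc2ccccc21`: in this assay compound 3 sits at the limit > 50000 nM, again a limit.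

All three measured values are limits, (the limit of > 50000 nM in this assay, at which 3 of the 3 values shown sit). The change hydrogen in place of methyl on a saturated chain carbon bound to an aromatic nitrogen and a saturated chain carbon gives a step that the two limits leave unreadable from compound 3 to compound 1. The change 2,6-dimethylmorpholin-4-yl in place of piperidin-1-yl on a carbonyl carbon gives a step that the two limits leave unreadable from compound 1 to compound 2. The difference between the cores of compound 2 and compound 3 is not broken down here.

Compound 4 `CC1CN(C(=O)CN2C(=O)S/C(=C\c3nc4ccccc4n3C)C2=O)CC(C)O1` is not yet measured. It differs from compound 2 by hydrogen in place of methyl on a saturated chain carbon bound to an aromatic nitrogen. This is the same kind of change as from compound 3 to compound 1, not the same: there the carbon is bound to an aromatic nitrogen and a saturated chain carbon, here to an aromatic nitrogen only.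

For compound 4 the expected step is a step that the limit leaves unreadable from compound 2 to compound 4, and this expectation rests on (the limit of > 50000 nM in this assay, at which 3 of the 3 values shown sit). Compound 4 is estimated at 100000 nM, with an expected range of 50000 nM to 500000 nM.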

Compound 4, half-maximal inhibitory concentration: > 50000 nM
Compound 4: only a limit was reported; the forecaster's own chance of this, stated with the estimate: 90%; the middle value does not contradict the limit.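

In this assay compound 4 gives > 50000 nM, a limit and not a number. Compound 2 sits at the same limit, so no step can be read between compound 2 and compound 4. The compounds shown leave open whether any of these changes affects inhibition at all, because every result is the same limit: the limit of > 50000 nM in this assay, at which 4 of the 4 values shown sit.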